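Swapping a chlorothiophene for a trifluoromethylphenyl

The source may report more compounds than this note shows. Statements on the series, on what has been measured and on what is new or still open speak of the compounds shown alone.

Of the compounds shown here, two that share a core have been measured in a functional assay on CHO cells for agonist activity at Free fatty acid receptor 1 (Homo sapiens), read by FLIPR and calcium flux, tested at 100 nM; a lower number here means a weaker effect, a higher number a stronger effect of the compound at the concentration tested. Compound 1, with the structure `O=C(O)CC1COc2cc(OCc3cc(-c4ccccc4)on3)ccc21`, gives 0.84% in this assay. Compound 2, with the structure `Cc1nc(-c2ccc(Cl)s2)sc1COc1ccc2c(c1)OCC2CC(=O)O`, gives 8.34% in this assay. Compound 2 carries the larger of these two numbers, but the gap to compound 1 lies within the usual scatter of repeated measurements, so the two cannot be told apart on these data, and both sit at the weak end of the scale.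

Compound 3, with the structure `Cc1nc(-c2cccc(C(F)(F)F)c2)sc1COc1ccc2c(c1)OCC2CC(=O)O`, has not yet been measured. It differs from compound 2 in one place: 3-(trifluoromethyl)phenyl in place of 5-chlorothiophen-2-yl on an aromatic carbon. Within the data shown here, no step between two measured compounds is known for this kind of change, so there is nothing in the data that points firmly up or down. The expectation is a small step, a number 3.7 percentage points higher from compound 2 to compound 3 (within the scatter), that most likely stays within the scatter. Compound 3 is therefore estimated to give 12% in this assay, expected to fall between 2% and 40%.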

Compound 3, a percentage reported as activity, at one concentration (the size of the read-out at that concentration, not a potency): 35.7%
Compound 3: middle estimate off by 23.7 percentage points, on the low side; measured number inside the range.
By their numbers in this assay, from the lowest: compounds 1 and 2 (each within the scatter of the next); then compound 3.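

In this assay, putting 3-(trifluoromethyl)phenyl in place of 5-chlorothiophen-2-yl, on the aromatic carbon next to the ring nitrogen and next to the ring sulfur, gives a number 27.4 percentage points higher from compound 2 to compound 3 (beyond the scatter). Among these compounds, this is the first difference in the set that can be read with confidence, and it shows that the group at this position can change the size of the response at the single concentration tested, a result that compound 1 and compound 2 could not provide because they differ in more than one place and cannot be told apart. Nothing in the available data explains why this exchange raises the response.

The step combines several differences at once, since the ring, its substituent and the number of heavy atoms all change, so these compounds do not show which of them matters. A 3-chlorophenyl group at the same position would separate the effect of changing the ring from that of changing its substituent, and a nitrile or methoxy group in place of the trifluoromethyl would show how much depends on that substituent.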